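Inverting one ring stereocentre: an expected step in potency

A few compounds are considered here, and "the series" means these few. Any claim that something is new, unique, unknown or untested is made for them only; others in the source may bear on it.

The measured part of the series holds compound 1 (`CCCCCCCNC[C@@H]1OC[C@H](N)[C@@H]1O`) and compound 2 (`CCCCCCCCCNC[C@@H]1OC[C@H](N)[C@H]1O`). In a functional assay on PC-3 cells (Homo sapiens) for antiproliferative activity, read by MTT assay, with a stated time of 72 h (a higher number here means a weaker inhibitor, a lower number a stronger inhibitor), compound 1 gives 22400 nM and compound 2 gives 7650 nM as the lower of the two numbers. The gap between them lies beyond the scatter, so compound 2 stands as the stronger inhibitor of the pair.

The next compound is compound 3 (`CCCCCCCCCNC[C@@H]1OC[C@H](N)[C@@H]1O`). Its relation to compound 2 is as follows: the two compounds have the same atoms and bonds and differ only in configuration as drawn: 1 of 3 stereo elements differ; a stereocentre at a saturated ring carbon is drawn R in compound 2 and S in compound 3 (a stereocentre at a saturated ring carbon is drawn R in compound 2 and S in compound 3).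

Among the compounds with values here, the series offers no measured pair that isolates such an inversion, so neither the size nor the direction of the step in this assay can be read from the data. No step beyond the scatter is the working expectation, and the estimate stays anchored on compound 2 at 7650 nM with a wide range on both sides. For compound 3 the expected value is 8000 nM (estimated range 3500 nM to 20000 nM). This estimate amounts to an expected 1.0-fold higher number from compound 2 to compound 3 (0.02 log units; within the scatter) (no clear direction).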

Compound 3, half-maximal inhibitory concentration: 2030 nM
The estimate for compound 3 lay 3.9-fold (0.60 log units) above the measured number; the whole stated range lies above it.
By their numbers in this assay, from the lowest: compound 3; then compound 2; then compound 1.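

In this assay, inverting the saturated ring carbon from R to S as drawn gives a 3.8-fold lower number from compound 2 to compound 3 (0.58 log units; beyond the scatter), so the configuration at this position affects the antiproliferative read-out, and the step can be assigned to that inversion alone because the pair has no other difference: the fact that compounds 2 and 3 differ only in the configuration as drawn

With the S configuration held, ethyl in place of hydrogen on a saturated chain carbon, seven bonds along the chain from an amine nitrogen, gives an 11-fold lower number from compound 1 to compound 3 (1.04 log units; beyond the scatter), the larger of the two steps in this short series. Each change now has its own step, which the earlier pair, differing in two places, could not provide.

Going by these compounds, whether the gain from added chain length continues with a longer chain, and whether the same inversion gives a step of similar size on the shorter chain of compound 1, remains open. Also open, on these data alone, are the effects of inverting the other ring stereocentres and of replacing the ring amine with a hydroxyl group or the chain amine with an amide.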